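A few compounds are considered here, and "the series" means these few. Any claim that something is new, unique, unknown or untested is made for them only; others in the source may bear on it.

In an ADME assay on CEM-SS cells (Homo sapiens) for cytotoxicity, read by XTT assay (on this read-out lower numbers stand for higher toxicity in this test and higher numbers for lower toxicity in this test), compound 1 `CN1CCN(Cc2cn(Cc3ccc(F)cc3)c3cnc(C(=O)N(C)O)cc23)CC1` gives > 224000 nM as a limit only. Compound 2 `CN(O)C(=O)c1cc2c(CN3CCNC(=O)C3)cn(Cc3ccc(F)cc3)c2cn1` gives > 100000 nM as a limit only. Compound 3 `COCCOCc1cn(Cc2ccc(F)cc2)c2cnc(C(=O)N(C)O)cc12` gives > 100000 nM as a limit too, so it has no number of its own. Compound 4 `CN(O)C(=O)c1cc2c(CCCO)cn(Cc3ccc(F)cc3)c2cn1` differs from compound 3 by 2-hydroxyethyl in place of 2-methoxyethoxy on a saturated chain carbon bound to an aromatic carbon with 2-hydroxyethyl in place of 2-methoxyethoxy on a saturated chain carbon bound to an aromatic carbon. The measured steps at this place are a step that the two limits leave unreadable from compound 1 to compound 2 and a step that the two limits leave unreadable from compound 1 to compound 3 and a step that the two limits leave unreadable from compound 2 to compound 3 and none has a readable size. Among the measured compounds shown here, with these steps as the only guide, no step beyond the scatter is expected in this assay in either direction. The expected step is a number no higher from compound 3 to compound 4 (the limit leaves the size open) and no larger. Compound 4 is estimated at 100000 nM within a range of 30000 nM to 250000 nM and is expected to read most likely as a limit.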

Compound 4, half-maximal cytotoxic concentration: > 10000 nM
Compound 4 was reported as a limit; the forecaster's own chance of this, stated with the estimate: 80%; the middle value is on the limit's open side.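

In this assay, among the compounds shown here, compound 1, compound 2, compound 3 and compound 4 all read only as limits, so no step among them can be read. The compounds shown leave open where any true half-maximal cytotoxic concentration lies, and whether these side-chain changes shift it at all.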